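Tolerated concentrations across three measured compounds and one pending

The source may hold more compounds than are shown below. What is called first, only, known or untested is meant among the compounds shown, and "the series" means these compounds.

Measured in an ADME assay on HEL cells (Homo sapiens) for cytotoxicity, with a stated time of 3 days; a lower number here means that less compound is tolerated, a higher number that more compound is tolerated:
Compound 1 `CCC1(Cc2ccccc2)OS(=O)(=O)CC1=O` gives > 100000 nM.
Compound 2 `CC1(C(c2ccccc2)c2ccccc2)OS(=O)(=O)C=C1OCc1ccccc1` gives >= 400000 nM.
Compound 3 `CCC1(Cc2ccccc2)OS(=O)(=O)C=C1NCc1ccccc1` gives >= 80000 nM.

Every value in hand is a limit of this assay, not a number. Compound 2 stands at the limit of >= 400000 nM in this assay, at which 1 of the 3 values shown sits, so its true position is known only as a limit. Compound 1 rests at the limit of > 100000 nM in this assay, at which 1 of the 3 values shown sits. Compound 3 rests at the limit of >= 80000 nM in this assay, at which 1 of the 3 values shown sits. Going by the values given here, no step between measured compounds is available, so no measured step can guide the next move.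

Compound 4 `CC1(Cc2ccccc2)OS(=O)(=O)C=C1OCc1ccccc1` differs from compound 2 as follows: hydrogen in place of phenyl on a saturated chain carbon bound to an aromatic carbon and a saturated ring carbon. The expected step in this assay is an at least 2.0-fold lower number from compound 2 to compound 4 (0.30 log units; that floor lies within the scatter), that is none beyond the scatter, because compound 2 already sits at the limit of >= 400000 nM in this assay, at which 1 of the 3 values shown sits, and the remaining compounds sit at limits too. Compound 4 is estimated at 200000 nM, within 50000 nM to 400000 nM, and is likely to be reported as a limit.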

Compound 4, minimum cytotoxic concentration: > 400000 nM
Compound 4 was reported as a limit; the forecaster's own chance of this, stated with the estimate: 80%; middle value at least 2.0-fold (0.30 log units) away from the limit.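

Compound 2 gives >= 400000 nM, a limit. Going by these compounds alone, compound 4 gives > 400000 nM, also a limit, so no step between the two can be read. The compounds shown leave open the concentration at which any of them turns cytotoxic in this assay.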